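The source may hold more compounds than are shown below. What is called first, only, known or untested is meant among the compounds shown, and "the series" means these compounds.

Compound 1, `COc1ccccc1N1CCN(CCCNC(=O)NN(Cc2ccccc2F)c2ccc(F)cc2)CC1`: 3.6 nM
Compound 2, `COc1ccccc1N1CCN(CCCNC(=O)NN(Cc2cccc(F)c2)c2ccc(F)cc2)CC1`: 3.8 nM
Compound 3, `COc1ccccc1N1CCN(CCCNC(=O)NN(Cc2ccc(C#N)cc2)c2ccc(F)cc2)CC1`: 15 nM

Three compounds sharing one core were measured in an assay on CHO cells for displacement of a labelled ligand from D(4) dopamine receptor (Homo sapiens), read by radioligand binding; on this read-out lower numbers stand for stronger inhibition and higher numbers for weaker inhibition. Compound 1 gives the lowest number of the three. Its nearest neighbour is compound 2, and the step of a 1.1-fold higher number from compound 1 to compound 2 (0.02 log units; within the scatter) is within the scatter, so the two cannot be ordered. The furthest is compound 3, reached by a 4.2-fold higher number from compound 1 to compound 3 (0.62 log units; beyond the scatter), a modest but real step; the related step of a 3.9-fold higher number from compound 2 to compound 3 (0.60 log units; beyond the scatter) is of similar size.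

Compound 4, `COc1ccccc1N1CCN(CCCNC(=O)NN(Cc2ccccc2F)c2ccc(Br)cc2)CC1`, differs from compound 1 by bromo in place of fluoro on an aromatic carbon. All three measured steps change the ring on the saturated chain carbon bound to the nitrogen, and none of them touches the ring where compound 4 is altered. Within the data shown here, no measured step therefore bears directly on this change, and the data give no basis for expecting a shift in either direction beyond the scatter. Compound 4 is accordingly expected to sit close to compound 1, with an estimated step of a 1.1-fold higher number from compound 1 to compound 4 (0.05 log units; within the scatter). For compound 4 the estimate in this assay is 4 nM, with a range from 1.5 nM to 12 nM.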

Compound 4, inhibition constant: 3.3 nM
Compound 4: middle estimate off by 1.2-fold (0.08 log units), on the high side; the range from low to high includes it.
By their numbers in this assay, from the lowest: compounds 4, 1 and 2 (each within the scatter of the next); then compound 3.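

Among these compounds, the earlier compounds changed only the ring on the saturated chain carbon, so compound 4 gives the first reading on the other ring, where 4-bromophenyl takes the place of 4-fluorophenyl. In this assay the step of a 1.1-fold lower number from compound 1 to compound 4 (0.04 log units; within the scatter) lies within the scatter, so the two compounds cannot be ordered, and this position, on an aromatic carbon para to a large group, holds either bromo or fluoro with no readable change in the number. Nothing available explains why these two groups read alike.

With only fluoro and bromo seen at this position, the compounds shown leave open how a group of another kind, such as methoxy, an amine or a carboxylic acid, would read there in this assay. Among the compounds shown here, they also leave open whether bromo would read the same alongside the 3-fluorophenyl or 4-cyanophenyl groups that stand on the chain carbon in compound 2 and compound 3, since the swap is seen only with the 2-fluorophenyl group of compound 1.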